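Swapping the aryl group of compound 3 for cyclopropyl

The source may hold more compounds than are shown below. What is called first, only, known or untested is meant among the compounds shown, and "the series" means these compounds.

Measured compounds:
compound 1 `CCOC(=O)c1cnc(C(F)(F)F)nc1NN1C(=O)C=C(C)C1=O`: 1000 nM
compound 2 `CCOC(=O)c1cnc(-c2ccncc2)nc1NN1C(=O)C=C(C)C1=O`: 6000 nM
compound 3 `CCOC(=O)c1cnc(-c2ccc(Cl)cc2)nc1NN1C(=O)C=C(C)C1=O`: 300 nM

In a functional assay on Jurkat cells for inhibition of nuclear factor NF-kappa-B complex (Homo sapiens) (on this read-out higher numbers stand for weaker inhibition and lower numbers for stronger inhibition), compound 3 gives the lowest number of the three, with compound 1 nearest and compound 2 furthest. Compound 4 `CCOC(=O)c1cnc(C2CC2)nc1NN1C(=O)C=C(C)C1=O` differs from compound 3 by cyclopropyl in place of 4-chlorophenyl on an aromatic carbon. Going by the values given here, no measured step swaps an aromatic ring for a non-aromatic ring at this position. The closest guide is a 3.3-fold lower number from compound 1 to compound 3 (0.52 log units; beyond the scatter), where a group that is not an aromatic ring gave way to 4-chlorophenyl; reversing that suggests a higher number. Compound 4 is therefore expected to show a 3.3-fold higher number from compound 3 to compound 4 (0.52 log units; beyond the scatter). The estimate for compound 4 is 1000 nM, within 300 nM to 4000 nM.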

Compound 4, half-maximal inhibitory concentration: 1000 nM
Estimate against measurement, compound 4: no gap at the digits printed; low and high end bracket the measured number.
By their numbers in this assay, from the lowest: compound 3; then compounds 1 and 4 (each within the scatter of the next); then compound 2.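

In this assay the non-aromatic cyclopropyl gives a 3.3-fold higher number from compound 3 to compound 4 (0.52 log units; beyond the scatter) against 4-chlorophenyl and a 6.0-fold lower number from compound 2 to compound 4 (0.78 log units; beyond the scatter) against pyridin-4-yl in the same place, so having an aromatic ring here does not by itself decide the number. Trifluoromethyl and cyclopropyl cannot be told apart, with no change at the digits printed from compound 1 to compound 4 (within the scatter) between them. Nothing measured here explains these steps. Still open, as far as these compounds go, is whether plain phenyl would match 4-chlorophenyl, showing what the chlorine adds. Also open, from the compounds shown here alone, is how a larger ring such as cyclohexyl, or an amine, would compare with cyclopropyl at this position.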